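Trifluoromethyl Addition in Two Pentafluorosulfanyl Anilide Series

The source may report more compounds than this note shows. Statements on the series, on what has been measured and on what is new or still open speak of the compounds shown alone.

In a functional assay on DU-145 cells (Homo sapiens) for antiproliferative activity, read by propidium iodide staining, with a stated time of 96 h (a lower number here means a stronger inhibitor, a higher number a weaker inhibitor), compound 1 `CC(O)(CSc1cccc(C(F)(F)F)c1)C(=O)Nc1ccc(S(F)(F)(F)(F)F)cc1` gives 26200 nM. Compound 2 `CC(O)(CSc1cc(C(F)(F)F)cc(C(F)(F)F)c1)C(=O)Nc1ccc(S(F)(F)(F)(F)F)cc1` carries the change trifluoromethyl in place of hydrogen on an aromatic carbon and in this assay compound 2 gives 29700 nM, so the step of a 1.1-fold higher number from compound 1 to compound 2 (0.05 log units; within the scatter) is flat. Compound 3 `CC(O)(COc1ccc(C#N)cc1)C(=O)Nc1cccc(S(F)(F)(F)(F)F)c1` gives 42600 nM in this assay; the difference between its core and the core of compound 1 is not broken down here. Compound 4 `CC(O)(COc1ccc(C#N)cc1C(F)(F)F)C(=O)Nc1cccc(S(F)(F)(F)(F)F)c1` differs from compound 3 by trifluoromethyl in place of hydrogen on an aromatic carbon. The surroundings differ: in compound 2 the entering group sits meta to a large group and meta to a trifluoromethyl group, in compound 4 ortho to a large group and meta to a cyano group, so this is the same kind of change, not the same one. Because the earlier step of a 1.1-fold higher number from compound 1 to compound 2 (0.05 log units; within the scatter) stayed within the scatter, only a small step is expected, a 1.1-fold higher number from compound 3 to compound 4 (0.02 log units; within the scatter). Compound 4 is therefore estimated at 45000 nM in this assay, between 20000 nM and 100000 nM.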

Compound 4, half-maximal inhibitory concentration: 22800 nM
The estimate for compound 4 lay 2.0-fold (0.30 log units) above the measured number, within the range that was stated.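

In this assay trifluoromethyl in place of hydrogen on an aromatic carbon gives a 1.9-fold lower number from compound 3 to compound 4 (0.27 log units; within the scatter) on the core of compound 3. The change reads alike on both cores: the same change on two cores in this assay, a 1.1-fold higher number (0.05 log units; within the scatter) from compound 1 to compound 2 and a 1.9-fold lower number (0.27 log units; within the scatter) from compound 3 to compound 4, 2.1-fold (0.33 log units) apart, within the scatter of two such steps. Neither step stands out from the scatter, but two pairs with the entering group in different surroundings do not show that the change would carry to further cores or to other places on the ring.

Still open, going by these compounds, is whether another group in the same place, such as an amine or a carboxylic acid, would move the number beyond the scatter. On these data alone, the separate contributions of the sulfur and oxygen links also remain open, as the cores of compound 1 and compound 3 differ in more than one place.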